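This account rests on a few compounds, and the source may have more. Where it says the series, first, only, none or still open, it means among the compounds named here.

Compound 1 `CCN(c1ccc(C#N)c(Cl)c1)c1cc(-n2cnc3ccccc32)ccc1C`: 8160 nM
Compound 2 `CCN(c1ccc(C#N)c(Cl)c1)c1cc(-c2ccnn2C)ccc1C`: 7290 nM

In a functional assay on PC-3 cells (Homo sapiens) for antiproliferative activity, read by CCK-8 assay, with a stated time of 6 days (a lower number here means a stronger inhibitor, a higher number a weaker inhibitor), compound 2 gives 7290 nM, which cannot be told apart from the value of compound 1. The next compound, compound 3 `CCN(c1ccc(C#N)c(Cl)c1)c1cc(-c2ccc(F)nc2)ccc1C`, carries 6-fluoropyridin-3-yl in place of 1-methyl-1H-pyrazol-5-yl on an aromatic carbon. Within the data shown here, only one measured step bears on this carbon, a 1.1-fold lower number from compound 1 to compound 2 (0.05 log units; within the scatter), and it is small. One step is thin evidence, but it gives no reason to expect a change beyond the scatter in this assay, in either direction. The expected step is a 1.1-fold lower number from compound 2 to compound 3 (0.05 log units; within the scatter). Compound 3 is estimated at 6500 nM, with a likely range of 2500 nM to 15000 nM.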

Compound 3, half-maximal inhibitory concentration: > 30000 nM
Compound 3: a limit, no number; the forecaster's own chance of this, stated with the estimate: 10%; middle value at least 4.6-fold (0.66 log units) from the limit.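

In this assay, this aromatic carbon proves not to be indifferent to the ring it carries: the change gives an at least 4.1-fold higher number from compound 2 to compound 3 (0.61 log units; beyond the scatter), and replacing 1H-benzimidazol-1-yl gives an at least 3.6-fold higher number from compound 1 to compound 3 (0.56 log units; beyond the scatter). The earlier pair had shown no change beyond the scatter here. Compound 3 gives > 30000 nM, a limit of the assay and not a number, so the full size of both steps stays unknown: the limit of > 30000 nM in this assay, at which 1 of the 3 values shown sits.

The compounds shown do not separate the fluorine from the six-membered ring that carries it. Going by these compounds, how an amine or a carboxylic acid on this carbon would behave also stays open.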